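A few compounds are considered here, and "the series" means these few. Any claim that something is new, unique, unknown or untested is made for them only; others in the source may bear on it.

Measured in an ADME assay on microsomes from liver (Mus musculus) for metabolic stability; a higher number here means that the compound lasts longer, a lower number that the compound disappears faster:
- Compound 1 `O=C(Nc1cccc(-c2nc3ccccc3s2)c1)c1cc([N+](=O)[O-])ccc1Cl`: 0.18 h
- Compound 2 `COc1ccc(-c2nc3ccccc3s2)cc1NC(=O)c1cc([N+](=O)[O-])ccc1Cl`: > 4 h (a limit of the assay, not a number)

Compound 2 stands at the limit of > 4 h in this assay, at which 1 of the 2 values shown sits. Compound 3 `Cc1ccc(-c2nc3ccccc3s2)cc1NC(=O)c1cc([N+](=O)[O-])ccc1Cl` has methyl in place of methoxy on an aromatic carbon, ortho to a large group and para to a 1,3-benzothiazol-2-yl group (methyl in place of methoxy on an aromatic carbon). Going by the values given here, the one measured step at this carbon is an at least 22-fold higher number from compound 1 to compound 2 (1.34 log units; beyond the scatter), with methoxy in place of hydrogen. Methyl is neither of those two groups, and the data do not show how it behaves here. Compound 3 is therefore expected to keep only part of that large gain in this assay, with a clear downward step. The expected change is an at least 2.6-fold lower number from compound 2 to compound 3 (0.42 log units; beyond the scatter). For compound 3 the half-life is estimated at 1.5 h, with an expected range of 0.4 h to 5 h.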

Compound 3, half-life: > 4 h
Compound 3: no number, only a limit; the forecaster's own chance of this, stated with the estimate: 25%; middle value at least 2.6-fold (0.42 log units) away from the limit.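

With methyl in place of hydrogen on this aromatic carbon, this assay shows an at least 22-fold higher number from compound 1 to compound 3 (1.34 log units; beyond the scatter), so the large gain first seen with methoxy does not require the oxygen of that group. Compound 3 gives > 4 h, which is a limit of the assay and not a number. Methoxy and methyl therefore cannot be ranked, and the step between them cannot be read: the limit of > 4 h in this assay, at which 2 of the 3 values shown sit.

The compounds shown leave open how long compound 2 and compound 3 actually last in this assay, since neither has a number. They also leave open whether a single fluorine atom, an amine or a longer chain such as ethoxy on this carbon would keep the same large gain over compound 1.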